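The compounds below may be only part of what the source reports. "The series", "measured", "known", "first", "only" and "open" are said of these compounds alone.

Going by the values given here, in an ADME assay on microsomes from liver (Homo sapiens) for metabolic stability, read by LC-MS, using NADPH, with a stated time of 10 min, tested at 10 uM (a lower number here means that the compound disappears faster, a higher number that the compound lasts longer), compound 1 `N#Cc1ccnc(Oc2nn(C3CCC3)c3ncnc(N)c23)c1` gives 2.35 h, the higher of the two true numbers so far. Compound 2 `Nc1ncnc2c1c(Oc1cc(C(F)(F)F)ccn1)nn2C1CCCC1` gives 0.333 h, well below it and beyond the scatter. Compound 3 `Nc1ncnc2c1c(Oc1cc(C(F)(F)F)ccn1)nn2[C@H]1CC[C@H](CO)CC1` gives > 2.41 h, which is a limit of the assay and not a number.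

The next compound is compound 4 `N#Cc1ccnc(Oc2nn([C@H]3C[C@H](O)C3)c3ncnc(N)c23)c1`. The change is hydroxy in place of hydrogen on a saturated ring carbon, that is, cyclobutyl to 3-hydroxycyclobutyl.

Among the compounds with values here, one measured step bears on this: an at least 7.2-fold higher number from compound 2 to compound 3 (0.85 log units; beyond the scatter), where 4-(hydroxymethyl)cyclohexyl replaces cyclopentyl. As far as these compounds go, its full size is unknown, as compound 3 stands at the limit of > 2.41 h in this assay, at which 1 of the 3 values shown sits. The parallel is loose, since that pair carries trifluoromethyl where compound 1 carries nitrile, and the hydroxy sits on a different ring.

In this assay, a rise is therefore expected, but a much smaller one than in the measured step, and it may stay within the scatter. The estimated change is a 1.4-fold higher number from compound 1 to compound 4 (0.13 log units; within the scatter). For compound 4 the expected half-life is 3.2 h, with an estimated range of 1.5 h to 7 h.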

Compound 4, half-life: > 2.41 h
Compound 4: only a limit was reported; the forecaster's own chance of this, stated with the estimate: 50%; the middle value lies beyond the limit too.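

In this assay compound 4 gives > 2.41 h, which is a limit of the assay and not a number. The step reads an at least 1.0-fold higher number from compound 1 to compound 4 (0.01 log units; that floor lies within the scatter), so the true size of the change cannot be read, but hydroxy on this saturated ring carbon gives no sign of a shorter half-life in the nitrile series. Earlier, the limit had been reached only with trifluoromethyl and 4-(hydroxymethyl)cyclohexyl; it is now also reached with nitrile and 3-hydroxycyclobutyl: the limit of > 2.41 h in this assay, at which 2 of the 4 values shown sit.

As far as these compounds go, how far the half-life of compound 4 extends past the limit remains open. Also open, from the compounds shown here alone, is whether an amine or a carboxylic acid on the same ring carbon would match hydroxy, and whether the other ring isomer of 3-hydroxycyclobutyl would do the same.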